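Changing the Amide Aryl Group: From Compound 1 to Compound 4

This account rests on a few compounds, and the source may have more. Where it says the series, first, only, none or still open, it means among the compounds named here.

Compound 1, `CCCCCN1C(=O)C/C(=C\c2cccc(C(=O)Nc3cccc(F)c3)c2)C1=O`, gives only a limit in this study: > 100000 nM
Compound 2, `Cc1cccc(NC(=O)c2cccc(/C=C3\CC(=O)N(c4ccccc4)C3=O)c2)c1`, likewise gives only a limit: > 100000 nM
Compound 3, `O=C(Nc1ccc(Cl)cc1)c1cccc(/C=C2\CC(=O)N(c3ccccc3)C2=O)c1`, likewise gives only a limit: > 100000 nM

All three compounds were tested in an ADME assay on SW480 cells (Homo sapiens) for cytotoxicity, read by MTT assay, with a stated time of 72 h; a higher number here means a weaker inhibitor, a lower number a stronger inhibitor. For compound 1 the result is a limit of the assay and not a number, so compound 1 stands only at the edge of what this assay can report. Compound 2 sits at a limit as well. Compound 3 sits at a limit too. Taken together, (the limit of > 100000 nM in this assay, at which 3 of the 3 values shown sit), so no compound in the set has a readable value. Going by the values given here, the one pair that differs in a single place is a step that the two limits leave unreadable from compound 2 to compound 3, and the two limits leave that step unreadable.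

Compound 4, `CCCCCN1C(=O)C/C(=C\c2cccc(C(=O)Nc3ccc(OC)cc3)c2)C1=O`, differs from compound 1 by 4-methoxyphenyl in place of 3-fluorophenyl on an amide-type nitrogen. Among the compounds with values here, no measured step covers this kind of change, and the single measured step is itself unreadable, so there is no evidence for a shift in either direction. Compound 1 being at the limit, > 100000 nM, the expectation for compound 4 is a result at or near that same limit, with an expected step of a number no higher from compound 1 to compound 4 (the limit leaves the size open). The estimate for compound 4 in this assay is therefore 100000 nM, within a range from 30000 nM to 300000 nM.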

Compound 4, half-maximal inhibitory concentration: > 100000 nM
Compound 4 gave a limit, no number (the forecaster's own chance of this, stated with the estimate: 80%); the middle value sits exactly at the limit.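

In this assay, going by these compounds alone, compound 1 and compound 4 both give only a limit, so the change from 3-fluorophenyl to 4-methoxyphenyl yields no step that can be read. The compounds shown leave open whether any change to the amide aryl group alters the result, and how strong any of these compounds is: the limit of > 100000 nM in this assay, at which 4 of the 4 values shown sit.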